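This account rests on a few compounds, and the source may have more. Where it says the series, first, only, none or still open, it means among the compounds named here.

Measured compounds in a functional assay on HL-60 cells (Homo sapiens) for inhibition, read by MTT assay, with a stated time of 72 h; on this read-out higher numbers stand for weaker inhibition and lower numbers for stronger inhibition:
compound 1 `C=C(C)c1cccc(N2CCN(C(=O)c3oc(C)nc3-c3ccccc3F)CC2)c1`; compound 1 gives "not active" (no number reported)
compound 2 `Cc1nc(-c2ccccc2F)c(C(=O)N2CCN(c3cc(Cl)ccc3C)CC2)o1`; compound 2 gives 229 nM
compound 3 `COc1ccc(Cl)cc1N1CCN(C(=O)c2oc(C)nc2-c2ccccc2F)CC1`; compound 3 gives 153 nM

Compound 3 holds the lower of the two numbers reported, but the step of a 1.5-fold lower number from compound 2 to compound 3 (0.18 log units; within the scatter) lies within the scatter, so compound 2 and compound 3 cannot be told apart on these data. Compound 1 has no number at all.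

Compound 4 `Cc1nc(-c2ccccc2F)c(C(=O)N2CCN(c3cc(F)cc(F)c3)CC2)o1` differs from compound 3 by 3,5-difluorophenyl in place of 5-chloro-2-methoxyphenyl on an amine nitrogen in a ring. For the measured compounds named here, the single measured step, a 1.5-fold lower number from compound 2 to compound 3 (0.18 log units; within the scatter), also changes a group on the aryl ring attached to the amine nitrogen in a ring, yet it swaps only one group and stays within the scatter, so it offers little guide. Compound 1, which carries another group on that same nitrogen, gives "not active" (no number reported), showing that this group can decide whether any inhibition is seen. Removing both the methoxy and the chlorine of compound 3 goes beyond anything measured, and a somewhat higher number is expected. Compound 4 is therefore estimated at 500 nM, within 150 nM to 2000 nM. This expected step is a 3.3-fold higher number from compound 3 to compound 4 (0.51 log units; beyond the scatter), toward weaker inhibition, with real uncertainty.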

Compound 4, half-maximal inhibitory concentration: 186 nM
Compound 4: middle estimate off by 2.7-fold (0.43 log units), on the high side; the measured number falls inside the stated range.
By their numbers in this assay, from the lowest: compounds 3, 4 and 2 (each within the scatter of the next).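

Changing the aryl group on the amine nitrogen in this assay gives a 1.2-fold higher number from compound 3 to compound 4 (0.08 log units; within the scatter), and a second change at the same place gives a 1.2-fold lower number from compound 2 to compound 4 (0.09 log units; within the scatter). For the compounds shown here, compound 4 carries 3,5-difluorophenyl, with neither the chlorine of compound 2 and compound 3 nor their methyl or methoxy, so these particular groups are not needed to hold a number in this range, a point the single earlier step between two closely related groups could not make. Even so, the group at this place cannot be changed freely, as compound 1 gives "not active" (no number reported), and nothing available here explains either observation.

Still open, on these data alone, is whether the aryl ring at this place would keep a similar number when it carries an amine or a carboxylic acid. Also open, as far as these compounds go, is which feature of the aryl group separates compound 1 from compound 4.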